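A New Group on Sulfur for Compound 3

The source may report more compounds than this note shows. Statements on the series, on what has been measured and on what is new or still open speak of the compounds shown alone.

Of the compounds shown here, two sharing one core have been measured in a functional assay on L1210 cells (Mus musculus) for inhibition, read by thymidine incorporation; a higher number here means that more compound is needed for the effect, a lower number that less compound is needed. There, compound 1 `C=CCSc1nc(N)nc2c1ncn2[C@H]1C[C@H](O)[C@@H](CO)O1` gives 5.5 uM, and compound 2 `Cc1cccc(CSc2nc(N)nc3c2ncn3[C@H]2C[C@H](O)[C@@H](CO)O2)n1` gives 64 uM, the higher of the two numbers. Compound 3 `Cn1cnc([N+](=O)[O-])c1Sc1nc(N)nc2c1ncn2[C@H]1C[C@H](O)[C@@H](CO)O1` keeps the same core but has not yet been measured. Its change from compound 2 is on the sulfur, where 1-methyl-4-nitro-1H-imidazol-5-yl takes the place of (6-methylpyridin-2-yl)methyl: 1-methyl-4-nitro-1H-imidazol-5-yl in place of (6-methylpyridin-2-yl)methyl on a sulfur.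

Among the measured compounds shown here, only one measured step bears on this, and it also alters the group on sulfur: a 12-fold higher number from compound 1 to compound 2 (1.07 log units; beyond the scatter). This large step shows that this assay can respond strongly to a change at this place. For the measured compounds named here, still, it is a single step, and no measured compound carries the new group. Compound 2 stands at the top of just two numbers, at 64 uM, so a move down seems more likely than a further move up. The expected change is a 5.3-fold lower number from compound 2 to compound 3 (0.73 log units; beyond the scatter), a clear step towards a lower number. For compound 3 the estimated value is 12 uM, with an expected range from 3 uM to 50 uM.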

Compound 3, concentration for half-maximal effect: 25 uM
Compound 3: middle estimate off by 2.1-fold (0.32 log units), on the low side; the range from low to high includes it.
By their numbers in this assay, from the lowest: compound 1; then compound 3; then compound 2.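

In this assay, the sulfur tolerates a group attached through an aromatic ring carbon rather than a saturated chain carbon, and this 1-methyl-4-nitro-1H-imidazol-5-yl group gives a 2.6-fold lower number from compound 2 to compound 3 (0.41 log units; beyond the scatter). Measured against the small allyl group, however, the same group gives a 4.5-fold higher number from compound 1 to compound 3 (0.66 log units; beyond the scatter), so compound 1 remains the lowest of the three and compound 3 takes the middle place, showing that a larger ring-bearing group on sulfur need not land at the top of the order. No available evidence explains why the number moves in either step.

Replacing (6-methylpyridin-2-yl)methyl changes the ring, adds a nitro group and alters the atom bound to sulfur all at once, so the compounds shown cannot assign the step to any one of these parts. A plain phenyl ring on the sulfur, or a 1-methylimidazol-5-yl group without the nitro, would begin to separate them, while a simple ethyl chain would test how far the allyl double bond matters.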